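A few compounds are considered here, and "the series" means these few. Any claim that something is new, unique, unknown or untested is made for them only; others in the source may bear on it.

Compound 1 `O=C(CCCCCCc1ccccc1F)N1CCCC1`, compound 2 `O=C(CCCCCCc1cccc(F)c1)N1CCCC1` and compound 3 `O=C(CCCCCCc1ccccc1Cl)N1CCCC1` share a pyrrolidine amide carrying a chain that ends in a fluoro- or chlorophenyl ring. In an assay on HEK293 cells for inhibition of N-acylethanolamine-hydrolyzing acid amidase (Rattus norvegicus), read by LC-MS, with a stated time of 30 min (a lower number here means a stronger inhibitor, a higher number a weaker inhibitor), compound 1 gives 13700 nM. In this assay compound 2 gives 7300 nM, and the two numbers sit within the scatter of each other, so no order between them can be claimed. The difference between the two cores of compound 1 and compound 2 is not broken down here. Compound 3 reaches only a limit of this assay, > 100000 nM, and not a number.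

The measured step chloro in place of fluoro on an aromatic carbon gives an at least 7.2-fold higher number from compound 1 to compound 3 (0.86 log units; beyond the scatter), and it is an at least because compound 3 sits at the limit of > 100000 nM in this assay, at which 1 of the 3 values shown sits.

Compound 4 `O=C(CCCCCCc1cccc(Cl)c1)N1CCCC1` has not yet been measured. Within the data shown here, the change from compound 2 to it, (chloro in place of fluoro on an aromatic carbon), is the same kind of change as the one from compound 1 to compound 3, with the difference that here the place is meta to a large group where before it was ortho to a large group. Since the change is of the same kind, a step of the same direction is expected from compound 2 to compound 4 in this assay, estimated at a 5.5-fold higher number from compound 2 to compound 4 (0.74 log units; beyond the scatter), resting on the step from compound 1 to compound 3 an at least 7.2-fold higher number from compound 1 to compound 3 (0.86 log units; beyond the scatter). Compound 4 is therefore expected to give about 40000 nM in this assay, somewhere between 10000 nM and 150000 nM.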

Compound 4, half-maximal inhibitory concentration: 3700 nM
For compound 4 the middle estimate is 11-fold (1.03 log units) above the measured one; measured number outside the range, below it.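

In this assay, chloro in place of fluoro on an aromatic carbon gives a 2.0-fold lower number from compound 2 to compound 4 (0.30 log units; within the scatter), so compound 2 and compound 4 cannot be put in an order. Set beside the earlier step on the core of compound 1, this shows that in this series the effect of the change did not carry over from one core to the other: the same change on two cores in this assay, an at least 7.2-fold higher number (0.86 log units; beyond the scatter) from compound 1 to compound 3 and a 2.0-fold lower number (0.30 log units; within the scatter) from compound 2 to compound 4, at least 14-fold (1.15 log units) apart, beyond the scatter of two such steps What the two pairs do not show is why the steps differ or how large the earlier one really is, for that step ends in a limit of the assay and not a number: the limit of > 100000 nM in this assay, at which 1 of the 4 values shown sits.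

With only two pairs, the compounds shown leave open which of the two steps is the more usual one, and whether a third core would follow the core of compound 1, the core of compound 2 or neither. On these data alone, it also remains open whether a bromo, methyl or trifluoromethyl group on the same aromatic carbon would behave like chloro or fluoro on each core, and whether either step would hold on a shorter or longer chain.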